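The source may hold more compounds than are shown below. What is called first, only, known or untested is meant among the compounds shown, and "the series" means these compounds.

Measured so far in a functional assay on SK-BR-3 cells (Homo sapiens) for antiproliferative activity; a higher number here means a weaker inhibitor, a lower number a stronger inhibitor:
- compound 1 `CCCNCCCOc1ccc2cc(NC(=O)c3ccc(O)c(CC=C(C)C)c3)c(=O)oc2c1C`: 990 nM
- compound 2 `CC(C)=CCc1cc(C(=O)Nc2cc3ccc(OCCCN(C)c4ccccc4)c(C)c3oc2=O)ccc1O`: limit of > 50000 nM
- compound 3 `CC(C)=CCc1cc(C(=O)Nc2cc3ccc(OCCCN(C)Cc4ccccc4)c(C)c3oc2=O)ccc1O`: 10700 nM

Compound 1 gives the lowest half-maximal inhibitory concentration of the two numbers available; its nearest neighbour is compound 3 at an 11-fold higher number from compound 1 to compound 3 (1.03 log units; beyond the scatter). For compound 2 this assay reports only a limit, (the limit of > 50000 nM in this assay, at which 1 of the 3 values shown sits). Both measured steps from compound 1 replace propylamino on the amine nitrogen: an at least 50-fold higher number from compound 1 to compound 2 (1.70 log units; beyond the scatter) and an 11-fold higher number from compound 1 to compound 3 (1.03 log units; beyond the scatter), the benzyl variant sitting an at least 4.6-fold lower number from compound 2 to compound 3 (0.66 log units; beyond the scatter).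

Compound 4 `CC(C)=CCc1cc(C(=O)Nc2cc3ccc(OCCCN[C@@H]4C[C@H]5CC[C@@H]4C5)c(C)c3oc2=O)ccc1O` alters the same position: a group of 7 heavy atoms (7 carbon; 2 five-membered non-aromatic rings of carbon only) in place of a group of 3 heavy atoms (3 carbon; no ring), on an amine nitrogen. The entering group carries no aromatic ring, unlike the phenyl and benzyl that enter in compound 2 and compound 3, so those steps bear on it only indirectly; they show that this nitrogen tolerates change poorly, and a weakening is expected, though of smaller size than either measured step. The step of a 2.5-fold higher number from compound 1 to compound 4 (0.40 log units; beyond the scatter) is the estimate here. Compound 4 is expected at 2500 nM in this assay, with a range from 800 nM to 8000 nM.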

Compound 4, half-maximal inhibitory concentration: 770 nM
Compound 4: middle estimate off by 3.2-fold (0.51 log units), on the high side, outside the stated range (below it).
By their numbers in this assay, from the lowest: compounds 4 and 1 (each within the scatter of the next); then compound 3. At a limit, above all of these: compound 2.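

In this assay, among these compounds, the amine nitrogen accepts a much larger group than the earlier compounds suggested: the step is a 1.3-fold lower number from compound 1 to compound 4 (0.11 log units; within the scatter), so the group of 7 heavy atoms with 2 five-membered non-aromatic rings and propyl cannot be told apart here. Size alone therefore does not account for the earlier losses, which go with the aromatic-ring groups on a nitrogen that also carries methyl: a 14-fold lower number from compound 3 to compound 4 (1.14 log units; beyond the scatter). The gap to the phenyl variant is an at least 64-fold lower number from compound 2 to compound 4 (1.81 log units; beyond the scatter), a bound rather than a measured difference, as compound 2 stands at a limit: the limit of > 50000 nM in this assay, at which 1 of the 4 values shown sits.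

Going by these compounds, whether those losses follow the aromatic ring or the extra methyl stays open. Methyl(propyl)amino and benzylamino would separate the two, and the opposite enantiomer of the entering group would test whether its stereochemistry matters.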